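From Phenoxy to a Thiadiazolyl Sulfanyl Group

The compounds below may be only part of what the source reports. "The series", "measured", "known", "first", "only" and "open" are said of these compounds alone.

Three compounds have been measured in a functional assay on MGC-803 cells (Homo sapiens) for antiproliferative activity, read by MTT assay, with a stated time of 48 h; on this read-out higher numbers stand for weaker inhibition and lower numbers for stronger inhibition:

Compound 1 `COc1ccc(CN(C(=O)Cn2cc(COc3ccc4c(C)cc(=O)oc4c3)nn2)c2cc(OC)c(OC)c(OC)c2)cc1`: 130 nM
Compound 2 `COc1ccc(CN(C(=O)Cn2cc(COc3ccccc3)nn2)c2cc(OC)c(OC)c(OC)c2)cc1`: 12500 nM
Compound 3 `COc1ccc(CN(C(=O)Cn2cc(CSC3=NCCS3)nn2)c2cc(OC)c(OC)c(OC)c2)cc1`: 1610 nM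

Compound 2 gives the highest number of the three and is the weakest inhibitor of the set. Compound 4 `COc1ccc(CN(C(=O)Cn2cc(CSc3nncs3)nn2)c2cc(OC)c(OC)c(OC)c2)cc1` departs from it at one place: (1,3,4-thiadiazol-2-yl)sulfanyl in place of phenoxy on a saturated chain carbon bound to an aromatic carbon. Here (1,3,4-thiadiazol-2-yl)sulfanyl stands in place of phenoxy on a saturated chain carbon bound to an aromatic carbon.

The most relevant measurement is the change at that same place, a 7.8-fold lower number from compound 2 to compound 3 (0.89 log units; beyond the scatter), which is a modest step. The other measured change, a 96-fold higher number from compound 1 to compound 2 (1.98 log units; beyond the scatter), is large, but it concerns a different group on the oxygen and bears on compound 4 only loosely. Within the data shown here, a modest move toward a lower number is therefore expected in this assay, resting on the single precedent of compound 3 at 1610 nM. The expected step is a 6.3-fold lower number from compound 2 to compound 4 (0.80 log units; beyond the scatter).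

For compound 4 the estimated value is 2000 nM, with an expected range of 500 nM to 8000 nM.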

Compound 4, half-maximal inhibitory concentration: 5000 nM
Compound 4: the middle estimate sits 2.5-fold (0.40 log units) below what was measured; measured number inside the range.
By their numbers in this assay, from the lowest: compound 1; then compound 3; then compound 4; then compound 2.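

In this assay, (1,3,4-thiadiazol-2-yl)sulfanyl in place of phenoxy gives a 2.5-fold lower number from compound 2 to compound 4 (0.40 log units; beyond the scatter) and so provides a second change at this place that lowers the number, though a different ring on the sulfur gave the earlier precedent. The ring on that sulfur also matters, as the aromatic ring of compound 4 in place of the non-aromatic ring of compound 3 gives a 3.1-fold higher number from compound 3 to compound 4 (0.49 log units; beyond the scatter) with the rest of the structure unchanged. Nothing measured here accounts for either step.

The compounds shown leave open whether the sulfur link or the ring attached to it drives the difference from phenoxy, as both change together in these steps. A phenylsulfanyl group on the same saturated chain carbon would separate these two contributions, and an amine such as piperidin-1-yl there remains an open case.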